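This account rests on a few compounds, and the source may have more. Where it says the series, first, only, none or still open, it means among the compounds named here.

Measured so far in a functional assay on blood for antagonist activity at thromboxane A2 receptor (Homo sapiens); a higher number here means weaker binding, a lower number tighter binding:
compound 1, `CC(=O)NCc1ccccc1-c1ccc(COC2CC[C@H](N3CCCCCC3)[C@H]2OC/C=C\CCC(=O)O)cc1` — 25.1 nM
compound 2, `O=C(O)CC/C=C\CO[C@H]1[C@@H](OCc2ccc(-c3ccccc3)cc2)CC[C@@H]1N1CCCCC1` — 10 nM; 7.94 nM (2 entries)
compound 3, `O=C(O)CC/C=C\CO[C@H]1[C@@H](OCc2ccc(-c3ccccc3)cc2)CC[C@@H]1N1CCCCCC1` — 5.01 nM

In this assay, among the compounds with values here, compound 1 gives 25.1 nM, the highest of the two single numbers so far. The nearest measured neighbour is compound 3 with 5.01 nM, a gap that lies beyond the scatter of repeated measurements. Compound 2 has several entries, (the several entries of compound 2 in this assay, 10 nM; 7.94 nM (2 entries)), which sit close to one another and give a sense of the reproducibility of this assay.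

Compound 4, `O=C(O)CC/C=C\CO[C@H]1C(OCc2ccc(-c3ccccc3O)cc2)CC[C@@H]1N1CCCCCC1`, has not yet been measured. It differs from compound 1 in one place: hydroxy in place of acetamidomethyl on an aromatic carbon. Within the data shown here, the change exchanges a larger substituent for a small one; nothing measured so far speaks directly to this exchange, since no pair of measured compounds differs in only that way.

Compound 4 is expected to give a lower number than compound 1, with a step beyond the scatter, a 3.1-fold lower number from compound 1 to compound 4 (0.50 log units; beyond the scatter). Compound 4 is estimated at 8 nM, with a range from 3 nM to 25 nM, an expectation anchored below by compound 3 because compound 3 gives 5.01 nM.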

Compound 4, dissociation constant: 15.9 nM
Compound 4: middle estimate off by 2.0-fold (0.30 log units), on the low side; low and high end bracket the measured number.
By their numbers in this assay, from the lowest: compound 3; then compounds 4 and 1 (each within the scatter of the next).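

In this assay, hydroxy in place of acetamidomethyl on this aromatic carbon, ortho to a large group, gives a 1.6-fold lower number from compound 1 to compound 4 (0.20 log units; within the scatter), so the two groups cannot be told apart here. Within the data shown here, this is the first direct reading at this position, and it shows that the number holds when the five-atom acetamidomethyl group gives way to a single oxygen, with the counts of hydrogen-bond donors and acceptors unchanged. The step is also comparable to the spread among repeated measurements: the several entries of compound 2 in this assay, 10 nM; 7.94 nM (2 entries)

The compounds shown leave open whether an amine or a methoxy group on this same carbon would give a similar number. They also leave open whether hydroxy would read the same on another carbon of that ring.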